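The compounds below may be only part of what the source reports. "The series", "measured", "known", "first", "only" and "open" are said of these compounds alone.

For the measured compounds named here, compound 3 `O=C1COc2ccc(-c3nn(-c4ccc(F)cc4)cc3-c3ccccc3)cc2N1` is the only member of the set carrying a five-membered ring with two nitrogens bearing a substituent on nitrogen; compound 1 `O=C1COc2ccc(-c3[nH]c(-c4ccc(F)cc4)nc3-c3ccccc3)cc2N1` and compound 2 `COc1ccc(-c2nc(-c3ccccc3)c(-c3ccc4c(c3)NC(=O)CO4)[nH]2)cc1` share the other core. In a functional assay on MV4-11 cells (Homo sapiens) for cytotoxicity, read by colorimetric assay and MTT assay, with a stated time of 3 days, tested at 20 uM (a higher number here means a weaker effect of the compound at the concentration tested, a lower number a stronger effect), compound 1 gives 1.1% and compound 2 gives 1.2%; the step of a number 0.1 percentage points higher from compound 1 to compound 2 (within the scatter) is within the scatter. Compound 3, by contrast, gives 92.6%, the highest of the three numbers, beyond the scatter from both compound 1 and compound 2.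

Compound 4 `Cc1ccccc1-n1cc(-c2ccccc2)c(-c2ccc3c(c2)NC(=O)CO3)n1` differs from compound 3 by 2-methylphenyl in place of 4-fluorophenyl on an aromatic nitrogen. Going by the values given here, no measured step touches this position: the only recorded step, that between compound 1 and compound 2, concerns a substituent on an aromatic carbon of the other core and was within the scatter, so it offers no direct guide here. Among the compounds with values here, with no bearing step, the working expectation is that compound 4 stays close to compound 3, and the expected step of a number 4.6 percentage points lower from compound 3 to compound 4 (within the scatter) is none beyond the scatter, though the range must be wide. Compound 4 is therefore estimated at 88%, between 55% and 100%.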

Compound 4, a percentage reported as activity, at one concentration (the size of the read-out at that concentration, not a potency): 54.2%
Compound 4: middle estimate off by 33.8 percentage points, on the high side; measured number below the stated range.
By their numbers in this assay, from the lowest: compounds 1 and 2 (each within the scatter of the next); then compound 4; then compound 3.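

The group on the aromatic nitrogen of the core of compound 3 is a position that responds: in this assay, the change to 2-methylphenyl gives a number 38.4 percentage points lower from compound 3 to compound 4 (beyond the scatter), a stronger effect and the only step shown on this core. Both groups count the same heavy atoms, no hydrogen-bond donors or acceptors and no net charge, so these counts do not separate them, and the added methyl, the lost fluoro and the changed place on the phenyl ring all travel together in this single step. No measurement at hand explains the size of this step.

Still open, on these data alone, is which of those three differences carries the step, something 4-methylphenyl or 2-fluorophenyl on the same nitrogen could separate. Also open, as far as these compounds go, is how a carboxylic acid or an amine on a longer chain would read at this position.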